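The source may hold more compounds than are shown below. What is called first, only, known or untested is meant among the compounds shown, and "the series" means these compounds.

Measured in a functional assay on U-251 cells (Homo sapiens) for cytotoxicity; on this read-out lower numbers stand for stronger inhibition of growth and higher numbers for weaker inhibition of growth:
- compound 1 `CSc1ccc(C2=C(c3ccc(F)c(F)c3)C(=O)N3CCCC3C2)cc1`: 15000 nM
- compound 2 `CSc1ccc(C2=C(c3ccc(C)c(C)c3)C(=O)N3CCCC3C2)cc1`: 10000 nM
- compound 3 `CSc1ccc(C2=C(c3ccc(OCC4CO4)cc3)C(=O)N3CCCC3C2)cc1`: 80 nM

Compound 3, at 80 nM, has the lowest number of the three and stands well clear of the other two. It is also the only one carrying (oxiran-2-yl)methoxy.

In compound 4 `CSc1ccc(C2=C(c3ccc(SC)cc3)C(=O)N3CCCC3C2)cc1`, methylsulfanyl stands in place of (oxiran-2-yl)methoxy on an aromatic carbon: methylsulfanyl in place of (oxiran-2-yl)methoxy on an aromatic carbon.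

Among the compounds with values here, only one measured step bears on this, and it concerns the same aryl group: a 1.5-fold lower number from compound 1 to compound 2 (0.18 log units; within the scatter), which lies within the scatter. It shows that exchanging one pair of small groups there did not move the number. Within the data shown here, no measured compound has methylsulfanyl at this place, and no step removes (oxiran-2-yl)methoxy directly, so the comparison rests on the values of compound 1 and compound 2.

Compound 4 is therefore expected to fall nearer those two than compound 3, with a large rise in the number. The expected step is a 75-fold higher number from compound 3 to compound 4 (1.88 log units; beyond the scatter). For compound 4 the estimated value is 6000 nM, with an expected range of 1000 nM to 20000 nM.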

Compound 4, concentration for 50% growth inhibition: 5000 nM
The estimate for compound 4 lay 1.2-fold (0.08 log units) above the measured number; the range from low to high includes it.
By their numbers in this assay, from the lowest: compound 3; then compounds 4, 2 and 1 (each within the scatter of the next, the first and the last beyond it).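

In this assay, within the data shown here, the step at this aromatic carbon gives a 63-fold higher number from compound 3 to compound 4 (1.80 log units; beyond the scatter) and is the first direct measure of removing (oxiran-2-yl)methoxy, so a small group para to a large group does not reproduce the low number of compound 3. The other steps place compound 4 with the earlier aryl variants: a 2.0-fold lower number from compound 2 to compound 4 (0.30 log units; within the scatter) is within the scatter, and a 3.0-fold lower number from compound 1 to compound 4 (0.48 log units; beyond the scatter) is beyond it but modest, far smaller than the step from compound 3. No measurement available here accounts for the size of the step from compound 3.

On these data alone, it remains open whether the low number follows the three-membered ring or the oxygen-linked chain that carries it. A propoxy chain or an amine on this aromatic carbon would help separate the two.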